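This account rests on a few compounds, and the source may have more. Where it says the series, first, only, none or still open, it means among the compounds named here.

In a functional assay on HEK293 cells for activation of melanin-concentrating hormone receptor 1 (Homo sapiens), read by inositol phosphate accumulation (on this read-out higher numbers stand for an effect only at larger amounts of compound and lower numbers for an effect already at smaller amounts), three compounds of one series have been measured. Compound 1 `CCCc1cc(NC)c2cc(NC(=O)/C=C/c3ccc(C(F)(F)F)cc3)ccc2n1` gives 150 nM, compound 2 `CCCc1cc(OC)c2cc(NC(=O)/C=C/c3ccc(C(F)(F)F)cc3)ccc2n1` gives 360 nM, and compound 3 `CCCc1cc(N)c2cc(NC(=O)/C=C/c3ccc(SC)cc3)ccc2n1` gives 71 nM. Compound 2 thus stands at the highest number of the three, with compound 1 nearest to it and compound 3 furthest away. The one single-point step among these is a 2.4-fold higher number from compound 1 to compound 2 (0.38 log units; beyond the scatter), a modest rise on going from methylamino to methoxy.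

Compound 4 `CCCc1cc(NC2CCC2)c2cc(NC(=O)/C=C/c3ccc(C(F)(F)F)cc3)ccc2n1` has not yet been measured in this assay. It differs from compound 2 in one place: cyclobutylamino in place of methoxy on an aromatic carbon. The step of a 2.4-fold higher number from compound 1 to compound 2 (0.38 log units; beyond the scatter) bears on this change, as it concerns the same pair of substituent types, methylamino and methoxy, on the same aromatic carbon; run in reverse, from methoxy back to an alkylamino group, it points to a lower number of roughly that size. Among the measured compounds shown here, no measured step shows what cyclobutyl in place of methyl on that nitrogen does, so the expectation rests on that single step alone and carries wide uncertainty. Compound 4 is estimated at 150 nM, with a range from 50 nM to 450 nM. The expected step in this assay is a 2.4-fold lower number from compound 2 to compound 4 (0.38 log units; beyond the scatter), a modest fall.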

Compound 4, half-maximal effective concentration: 270 nM
For compound 4 the middle estimate is 1.8-fold (0.26 log units) below the measured one; measured number inside the range.
By their numbers in this assay, from the lowest: compound 3; then compounds 1, 4 and 2 (each within the scatter of the next, the first and the last beyond it).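

In this assay, cyclobutylamino in place of methoxy on this aromatic carbon gives a 1.3-fold lower number from compound 2 to compound 4 (0.12 log units; within the scatter), so the gap between methylamino and methoxy in compound 1 and compound 2 does not recur with this alkylamino group, and compound 4 cannot be told apart from compound 2. Among the compounds shown here, the step on the nitrogen itself, a 1.8-fold higher number from compound 1 to compound 4 (0.26 log units; within the scatter), shows something the earlier compounds could not: cyclobutyl in place of methyl, which brings in a four-membered ring of carbon only, also stays within the scatter, so compound 4 cannot be told apart from compound 1 either, even though compound 1 and compound 2 stand apart. Nothing measured here offers an explanation for this result.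

Going by these compounds, what a tertiary amine such as dimethylamino, a longer chain such as n-butylamino, or a larger ring such as cyclohexylamino would do on this aromatic carbon stays open. Also open, on these data alone, is how the plain amino group would compare with methylamino, since compound 3 carries it alongside a methylthio group in place of trifluoromethyl, and so differs from compound 1 in two places.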